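Chloro for nitro on the shared core: compound 4

The compounds below may be only part of what the source reports. "The series", "measured", "known", "first", "only" and "open" are said of these compounds alone.

Measured so far in a functional assay on HeLa cells (Homo sapiens) for cytotoxicity, read by MTT assay, with a stated time of 48 h; a lower number here means a stronger inhibitor, a higher number a weaker inhibitor:
compound 1 `COc1cc(C(=O)NC2CCN(C)CC2)ccc1Nc1ncc(F)c(NC2CCCC2)n1`, compound 1 gives 2200 nM
compound 2 `CN1CCC(NC(=O)c2ccc(Nc3ncc([N+](=O)[O-])c(NC4CCCC4)n3)cc2)CC1`, compound 2 gives 21700 nM
compound 3 `CCCNc1nc(Nc2ccc(N3CCN(C)CC3)cc2)ncc1F`, compound 3 gives 14200 nM

Among these three numbers compound 2 sits at the top, but its gap to compound 3 lies within the scatter, so the two cannot be told apart; only compound 1 lies beyond the scatter from compound 2. For the measured compounds named here, no pair of these measured compounds differs in a single place, so no measured step is available to lean on.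

Compound 4 `CN1CCC(NC(=O)c2ccc(Nc3ncc(Cl)c(NC4CCCC4)n3)cc2)CC1` is the next one for this assay. Against compound 2 it shows one change: chloro in place of nitro on an aromatic carbon. The chloro keeps the cyclopentylamino group and the rest of compound 2 unchanged.

Without a measured step of this kind, the expectation rests on the fact that compound 2 gives 21700 nM while the other two cores carry a small halogen. The step is expected to lower the number, to a moderate extent beyond the scatter, as a 4.3-fold lower number from compound 2 to compound 4 (0.64 log units; beyond the scatter). Compound 4 is estimated at 5000 nM, with a range from 1500 nM to 15000 nM.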

Compound 4, half-maximal inhibitory concentration: 1500 nM
Beside the measured number, compound 4's estimate is 3.3-fold (0.52 log units) above it; measured number inside the range.
By their numbers in this assay, from the lowest: compounds 4 and 1 (each within the scatter of the next); then compounds 3 and 2 (each within the scatter of the next).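

In this assay the position ortho to a cyclopentylamino group and para to a large group now has its first single-place read-out: a 14-fold lower number from compound 2 to compound 4 (1.16 log units; beyond the scatter) for chloro in place of nitro, a large step with the cyclopentylamino group and the rest of compound 2 unchanged. The earlier compounds shown here differed from one another in more than one place and could assign no gap to this position, whereas this pair shows that the number responds strongly to the group on this aromatic carbon. The exchange replaces three heavy atoms and two hydrogen-bond acceptors with one heavy atom and no acceptor, but no measurement on hand separates these differences or identifies what lies behind the step.

How a methyl, a nitrile or a primary amine on this aromatic carbon would read remains open, as the series shown gives only nitro and chloro on an otherwise unchanged compound. Also open is whether the step carries over to the cores of compound 1 and compound 3, since no pair shown tests this exchange on either.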